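A few compounds are considered here, and "the series" means these few. Any claim that something is new, unique, unknown or untested is made for them only; others in the source may bear on it.

Three compounds have been measured in a functional assay on MCF7 cells (Homo sapiens), read by MTT assay, with a stated time of 48 h; on this read-out higher numbers stand for weaker inhibition and lower numbers for stronger inhibition:

Compound 1, `CCn1c(C(=O)NCCCN(C)C)ccc1C(CC)(CC)c1ccc(OCC(=O)C(C)(C)C)c(C)c1`, gives 340 nM.
Compound 2, `CCN(CC)CCCNC(=O)c1ccc(C(CC)(CC)c2ccc(OCC(=O)C(C)(C)C)c(C)c2)n1CC`, gives 530 nM.
Compound 3, `CCN(CC)CCNC(=O)c1ccc(C(CC)(CC)c2ccc(OCC(O)C(C)(C)C)c(C)c2)n1CC`, gives 690 nM.

Compound 3 and compound 2 lie within the scatter of each other in this assay, while compound 3 and compound 1 lie beyond it. The difference between the core of compound 3 and the core of compound 2 is not broken down here.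

One change is seen twice among these compounds. From compound 2 to compound 1 it is dimethylamino in place of diethylamino on a saturated chain carbon, three bonds along the chain from an amide-type nitrogen, and the measured step is a 1.6-fold lower number from compound 2 to compound 1 (0.19 log units; within the scatter). The unmeasured compound 4, `CCn1c(C(=O)NCCN(C)C)ccc1C(CC)(CC)c1ccc(OCC(O)C(C)(C)C)c(C)c1`, differs from compound 3 by dimethylamino in place of diethylamino on a saturated chain carbon, two bonds along the chain from an amide-type nitrogen. The two places are not the same word for word: in compound 1 the group sits three bonds along the chain from an amide-type nitrogen, in compound 4 two bonds along the chain from an amide-type nitrogen, so this is the same kind of change rather than the same change.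

Because a 1.6-fold lower number from compound 2 to compound 1 (0.19 log units; within the scatter) stayed within the scatter, the expected step is also a small one, a 1.4-fold lower number from compound 3 to compound 4 (0.14 log units; within the scatter). For the measured compounds named here, compound 4 is therefore estimated at 500 nM in this assay, with a plausible range from 250 nM to 1000 nM, the width reflecting that only one earlier example of this kind of change is available and that it sits at a different place.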

Compound 4, half-maximal inhibitory concentration: 660 nM
Compound 4: middle estimate off by 1.3-fold (0.12 log units), on the low side, within the range that was stated.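

In this assay, the exchange of diethylamino for dimethylamino on the core of compound 3 reads as a 1.0-fold lower number from compound 3 to compound 4 (0.02 log units; within the scatter), and set beside the same kind of exchange on the core of compound 2, the two steps do not differ: the same change on two cores in this assay, a 1.6-fold lower number (0.19 log units; within the scatter) from compound 2 to compound 1 and a 1.0-fold lower number (0.02 log units; within the scatter) from compound 3 to compound 4, 1.5-fold (0.17 log units) apart, within the scatter of two such steps
In both cases shown, then, the exchange carries over from one core to the other as a step that cannot be told apart from the scatter, so neither core gives a sign that this change matters for the number read in this cell assay. This does not show that the change would stay as small on every core in the series, since the two examples also differ in where the group sits, three bonds along the chain from an amide-type nitrogen in one and two bonds along it in the other, and two steps this small are a weak test of whether a real effect transfers.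

The compounds shown leave open whether anything other than these two amino groups at the chain end, such as a primary amine or a carboxylic acid, would give a step beyond the scatter. They also leave open how a longer chain between the amide-type nitrogen and the amino group would read.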